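A few compounds are considered here, and "the series" means these few. Any claim that something is new, unique, unknown or untested is made for them only; others in the source may bear on it.

Measured compounds:
Compound 1, `CN(C)c1ccc(C2CC(c3ccc(-n4cncn4)cc3)=NN2C(=O)c2ccc(C(F)(F)F)cc2)cc1`, gives 7% in a functional assay on HCC1806 cells (Homo sapiens) for inhibition, read by sulforhodamine B assay, tested at 10 uM; a higher number here means more inhibition at the concentration tested (going by the name of the read-out), a lower number less inhibition.
Compound 2, `CN(C)c1ccc(C2CC(c3ccc(-n4ccnc4)cc3)=NN2C(=O)c2ccc(F)cc2)cc1`, gives 7.1% in this assay.
Compound 3, `CN(C)c1ccc(C2CC(c3ccc(-n4ccnc4)cc3)=NN2C(=O)c2cc(Cl)cc(Cl)c2)cc1`, gives 44.5% in this assay.

Compound 3 stands highest of the three numbers in this assay; compound 2 is nearest and compound 1 furthest, and both sit lower by a step beyond the scatter. Within the data shown here, the one measured step that changes the group on the carbonyl carbon is a number 37.4 percentage points higher from compound 2 to compound 3 (beyond the scatter), a large rise. Compound 4, `CN(C)c1ccc(C2CC(c3ccc(-n4ccnc4)cc3)=NN2C(=O)c2ccc(C(F)(F)F)cc2)cc1`, has not yet been measured in this assay. It differs from compound 3 in one place: 4-(trifluoromethyl)phenyl in place of 3,5-dichlorophenyl on a carbonyl carbon. Among the measured compounds shown here, no measured step links compound 1 to compound 4, as the two also differ in their azole; what their values show is only that compound 1, which carries the same 4-(trifluoromethyl)phenyl, sits low. The step from compound 2 to compound 3 bears on the change in the reverse sense: gaining the 3,5-dichlorophenyl brought a large rise, and giving it up for another single-ring group is expected to give back most of that rise. Compound 4 is therefore expected to drop by a number 32.5 percentage points lower from compound 3 to compound 4 (beyond the scatter) in this assay, landing near the low values of compound 1 and compound 2. Compound 4 is estimated at 12% in this assay, within 0% to 30%.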

Compound 4, a percentage reported as inhibition, at one concentration (the size of the read-out at that concentration, not a potency): 28%
Compound 4: the middle estimate sits 16 percentage points below what was measured; measured number inside the range.
By their numbers in this assay, from the lowest: compounds 1 and 2 (each within the scatter of the next); then compound 4; then compound 3.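

Moving away from the 3,5-dichlorophenyl on the carbonyl carbon does not cost the whole of the reading in this assay: with 4-(trifluoromethyl)phenyl in its place, the number is a number 16.5 percentage points lower from compound 3 to compound 4 (beyond the scatter) and stays well clear of the low pair. The single-ring groups at this position therefore do not behave alike, as trifluoromethyl in place of fluoro on an aromatic carbon gives a number 20.9 percentage points higher from compound 2 to compound 4 (beyond the scatter) in the same assay. Among these compounds, the azole also counts, which no earlier step could show: 1H-imidazol-1-yl in place of 1H-1,2,4-triazol-1-yl gives a number 21 percentage points higher from compound 1 to compound 4 (beyond the scatter) with the carbonyl group held constant, so the low value of compound 1 does not carry over to compound 4.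

No measurement at hand gives a reason for any of these steps. Still open, going by these compounds, is how the 3,5-dichlorophenyl fares alongside the 1H-1,2,4-triazol-1-yl, and whether an amine or a carboxylic acid in place of the trifluoromethyl would keep the reading in this assay at this level.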